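Fluoro-to-chloro exchange on the pendant phenyl of compound 1

The source may report more compounds than this note shows. Statements on the series, on what has been measured and on what is new or still open speak of the compounds shown alone.

Compound 1 `Cc1ccc(Oc2c(/C=N\OCc3c(Cl)c(-c4ccc(F)cc4)nn3C)c(C)nn2C)cc1` is the reference point of this pair. In a functional assay on SGC-7901 cells (Homo sapiens) for antiproliferative activity, read by MTT assay, with a stated time of 72 h (on this read-out lower numbers stand for stronger inhibition and higher numbers for weaker inhibition), compound 1 gives 4620 nM, the higher of the two numbers in hand. Its nearest neighbour is compound 2 `COc1ccc(Oc2c(/C=N\OCc3c(Cl)c(-c4ccc(F)cc4)nn3C)c(C)nn2C)cc1`, which in this assay gives 2840 nM; the change a 1.6-fold lower number from compound 1 to compound 2 (0.21 log units; within the scatter) replaces methyl with methoxy on the aryl ether and stays within the scatter. Compound 3 `Cc1ccc(Oc2c(/C=N\OCc3c(Cl)c(-c4ccc(Cl)cc4)nn3C)c(C)nn2C)cc1` differs from compound 1 at the other aryl group: chloro in place of fluoro on an aromatic carbon. For the measured compounds named here, no measured step touches this position, and the one step known, from compound 1 to compound 2, altered a different ring and produced nothing beyond the scatter. With no evidence of sensitivity at this site, the step in this assay is expected to be small, with no clear direction, and compound 3 is estimated at 4000 nM, with a range from 1500 nM to 12000 nM, corresponding to an expected step of a 1.2-fold lower number from compound 1 to compound 3 (0.06 log units; within the scatter).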

Compound 3, half-maximal inhibitory concentration: 3730 nM
Compound 3: the middle estimate sits 1.1-fold (0.03 log units) above what was measured; measured number inside the range.
By their numbers in this assay, from the lowest: compounds 2, 3 and 1 (each within the scatter of the next).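

In this assay, the first read on the pendant aryl group, the exchange of 4-fluorophenyl for 4-chlorophenyl gives a 1.2-fold lower number from compound 1 to compound 3 (0.09 log units; within the scatter), so these two halogens are not told apart on this ring. Alongside a 1.6-fold lower number from compound 1 to compound 2 (0.21 log units; within the scatter), this means single changes on two different aryl groups have both stayed within the scatter, and neither site has yet shown sensitivity. No supporting data bear on the origin of this flat result.

On these data alone, whether an amine, a carboxylic acid or a longer chain on this same aromatic carbon would move the number beyond the scatter remains open. Also open, as far as these compounds go, is whether the exchange of fluoro for chloro behaves the same way on the methoxy aryl ether of compound 2.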